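Taking the bromo group off compound 3

The source may report more compounds than this note shows. Statements on the series, on what has been measured and on what is new or still open speak of the compounds shown alone.

In a functional assay on HeLa cells (Homo sapiens) for antiproliferative activity, read by cell counting, with a stated time of 72 h (on this read-out higher numbers stand for weaker inhibition and lower numbers for stronger inhibition), compound 1 `C#C[C@@]1(O)[C@@H](CO)O[C@@H](n2cc(F)c3c(N)ncnc32)[C@@H]1O` gives 150 nM, compound 2 `C#C[C@@]1(O)[C@@H](CO)O[C@@H](n2cc(Cl)c3c(Cl)ccnc32)[C@@H]1O` gives 6300 nM, and compound 3 `C#C[C@@]1(O)[C@@H](CO)O[C@@H](n2cc(Br)c3c(Cl)ccnc32)[C@@H]1O` gives 890 nM, the middle of the three numbers. Compound 4 `C#C[C@@]1(O)[C@@H](CO)O[C@@H](n2ccc3c(Cl)ccnc32)[C@@H]1O` has not been measured. It differs from compound 3 by hydrogen in place of bromo on an aromatic carbon. For the measured compounds named here, only one measured step touches this place, the swap of chloro for bromo, a 7.1-fold lower number from compound 2 to compound 3 (0.85 log units; beyond the scatter), a modest step beyond the scatter. Going by the values given here, no compound without a halogen there has a number yet, so the guess is loose. A step of similar size towards a higher number is expected in this assay, namely a 4.5-fold higher number from compound 3 to compound 4 (0.65 log units; beyond the scatter). Compound 4 is estimated at 4000 nM, with an expected range of 800 nM to 20000 nM.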

Compound 4, half-maximal inhibitory concentration: 135000 nM
Compound 4: middle estimate off by 34-fold (1.53 log units), on the low side, outside the stated range (above it).
By their numbers in this assay, from the lowest: compound 1; then compound 3; then compound 2; then compound 4.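

In this assay, having a halogen on this aromatic carbon counts for far more than which halogen it is. Hydrogen in place of bromo gives a 150-fold higher number from compound 3 to compound 4 (2.18 log units; beyond the scatter), and hydrogen in place of chloro gives a 21-fold higher number from compound 2 to compound 4 (1.33 log units; beyond the scatter), both large steps next to the modest 7.1-fold lower number from compound 2 to compound 3 (0.85 log units; beyond the scatter). Nothing available explains why losing the halogen has so large an effect.

On these data alone, whether iodo would lower the number further remains open. So does whether a non-halogen group on this carbon, such as methyl, a nitrile or an amine, could match bromo.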